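Phenyl for methyl on the amide of compound 3

A few compounds are considered here, and "the series" means these few. Any claim that something is new, unique, unknown or untested is made for them only; others in the source may bear on it.

Measured compounds in an assay for inhibition of Nitric oxide synthase, inducible (Homo sapiens), read by scintillation counting, with a stated time of 30 min, tested at 1 mM; a lower number here means less inhibition, a higher number more inhibition at the concentration tested (going by the name of the read-out):
Compound 1, `COc1ccc(N)c(C(=O)CCNC(C)=O)c1`, gives 30.7%.
Compound 2, `COc1ccc(N)c(C(=O)CCNC(=O)C2CCCCC2)c1`, gives 9.24%.
Compound 3, `CC(=O)NCCC(=O)c1cc(Cl)ccc1N`, gives 19.7%.

Compound 3 stands second highest of the three numbers shown. Its nearest neighbour is compound 2, whose number is lower, and furthest from it lies compound 1, whose number is higher; both gaps exceed the scatter. The step from compound 1 to compound 3, chloro in place of methoxy on an aromatic carbon, gave a number 11 percentage points lower from compound 1 to compound 3 (beyond the scatter).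

Compound 4, `Nc1ccc(Cl)cc1C(=O)CCNC(=O)c1ccccc1`, has not yet been measured. It differs from compound 3 by phenyl in place of methyl on a carbonyl carbon. Among the compounds with values here, the one measured step that bears on this change is the enlargement of the same amide substituent, cyclohexyl in place of methyl on a carbonyl carbon, which gave a number 21.5 percentage points lower from compound 1 to compound 2 (beyond the scatter). A phenyl group is a different six-membered ring, yet it occupies the same position, so a downward step of broadly similar size is expected, with the read-out already low enough that it cannot fall much further.

Compound 4 is therefore expected to show a number 14.7 percentage points lower from compound 3 to compound 4 (beyond the scatter), with an estimated value of 5% and a likely range from -10% to 20%.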

Compound 4, a percentage reported as inhibition, at one concentration (the size of the read-out at that concentration, not a potency): 26.6%
Estimate against measurement, compound 4: 21.6 percentage points below, outside the stated range (above it).
By their numbers in this assay, from the lowest: compound 2; then compounds 3, 4 and 1 (each within the scatter of the next, the first and the last beyond it).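

In this assay, phenyl in place of methyl on a carbonyl carbon whose other neighbour is an amide-type nitrogen gave a number 6.9 percentage points higher from compound 3 to compound 4 (within the scatter), so on the core of compound 3 this position accepts the exchange of a methyl of 1 heavy atom for a phenyl of 6 heavy atoms with no change that can be told from scatter. Within the data shown here, the only earlier change at this place, cyclohexyl in place of methyl, gave a number 21.5 percentage points lower from compound 1 to compound 2 (beyond the scatter), so a loss on enlarging this group is not general: compound 2 shows it and compound 4 does not, although the two steps start from different cores, one with methoxy and one with chloro on the aromatic carbon. Nothing measured here accounts for the difference between the two steps.

Going by these compounds, it remains open whether phenyl would also leave the number unchanged on the core of compound 1, and whether cyclohexyl would lower it on the core of compound 3. The compounds shown also say nothing about how a benzyl group, a longer alkyl chain or a carboxylic acid would read at this carbonyl carbon.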